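From pyridin-2-yl to 1,3,4-thiadiazol-2-yl on a sulfur

The source may hold more compounds than are shown below. What is called first, only, known or untested is meant among the compounds shown, and "the series" means these compounds.

Measured in a functional assay on KYSE-70 cells for antiproliferative activity against KYSE-70 cell line (Homo sapiens), read by MTT assay, with a stated time of 72 h; on this read-out lower numbers stand for stronger inhibition and higher numbers for weaker inhibition:
Compound 1 `C#CCSc1nc(Sc2nc(C)c(C)s2)c(C#N)c(-c2cc(OC)c(OC)c(OC)c2)n1` gives > 20000 nM as a limit
Compound 2 `C#CCSc1nc(Sc2ccccn2)c(C#N)c(-c2cc(OC)c(OC)c(OC)c2)n1` gives > 10000 nM as a limit
Compound 3 `C#CCSc1nc(Sc2nccs2)c(C#N)c(-c2ccc(Br)cc2)n1` gives 10900 nM as a number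

Compound 2 has no number, only a limit (the limit of > 10000 nM in this assay, at which 1 of the 3 values shown sits). The step followed here leads to compound 4 `C#CCSc1nc(Sc2nncs2)c(C#N)c(-c2cc(OC)c(OC)c(OC)c2)n1`, which carries 1,3,4-thiadiazol-2-yl in place of pyridin-2-yl on a sulfur. Among the measured compounds shown here, only one measured step bears on this place (a step that the two limits leave unreadable from compound 1 to compound 2), and its size cannot be read. Compound 1 also has only a limit (the limit of > 20000 nM in this assay, at which 1 of the 3 values shown sits). The measurements therefore give no direction, and no step beyond the scatter is expected (a step that the limit leaves unreadable from compound 2 to compound 4). Compound 4 is estimated at 15000 nM, with an expected range from 6000 nM to 40000 nM in this estimate.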

Compound 4, half-maximal inhibitory concentration: 8250 nM
The estimate for compound 4 lay 1.8-fold (0.26 log units) above the measured number, and the stated range covers the measured number.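

With 1,3,4-thiadiazol-2-yl on the sulfur, compound 4 gives a number where the two earlier groups on this core gave only limits, and the change from 4,5-dimethyl-1,3-thiazol-2-yl reads as an at least 2.4-fold lower number from compound 1 to compound 4 (0.38 log units; beyond the scatter). Against pyridin-2-yl, the data show only an at least 1.2-fold lower number from compound 2 to compound 4 (0.08 log units; that floor lies within the scatter). This step has no exact size because compound 2 has only a limit: the limit of > 10000 nM in this assay, at which 1 of the 4 values shown sits.

The compounds shown leave open whether a 1,3,4-oxadiazol-2-yl or a 5-amino-1,3,4-thiadiazol-2-yl group on this sulfur would give a lower number.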